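This account rests on a few compounds, and the source may have more. Where it says the series, first, only, none or still open, it means among the compounds named here.

Measured so far in a functional assay on L1210 cells (Mus musculus) for antiproliferative activity, read by cell counting, with a stated time of 2 days; a lower number here means a stronger inhibitor, a higher number a weaker inhibitor:
- compound 1 `COc1ccc(Nc2nc(N)c(C(=O)c3ccc(Cl)cc3)s2)cc1`: 84 nM
- compound 2 `COc1ccc(Nc2nc(N)c(C(=O)c3ccccc3OC)s2)cc1`: 31 nM

Among the measured compounds shown here, compound 2 holds the lower of these two numbers, and compound 1 at 84 nM is its only neighbour. Compound 3 `COc1ccc(Nc2nc(N)c(C(=O)c3cccc(OC)c3)s2)cc1` has not yet been measured. It has 3-methoxyphenyl in place of the 2-methoxyphenyl of compound 2, on a carbonyl carbon: 3-methoxyphenyl in place of 2-methoxyphenyl on a carbonyl carbon. For the measured compounds named here, only one measured step bears on this change, a 2.7-fold lower number from compound 1 to compound 2 (0.43 log units; beyond the scatter), and it was modest. That step exchanged a different group at the same place, so the data do not show directly what moving the methoxy group does. Going by the values given here, a similarly modest step is expected in this assay, more likely upward, as compound 2 at 31 nM is the lowest number so far. The step estimated here is a 1.9-fold higher number from compound 2 to compound 3 (0.29 log units; within the scatter). For compound 3 the expected value is 60 nM, with an estimated range of 20 nM to 180 nM.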

Compound 3, half-maximal inhibitory concentration: 35 nM
Beside the measured number, compound 3's estimate is 1.7-fold (0.23 log units) above it; the range from low to high includes it.
By their numbers in this assay, from the lowest: compounds 2 and 3 (each within the scatter of the next); then compound 1.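

In this assay, moving the methoxy group gives a 1.1-fold higher number from compound 2 to compound 3 (0.05 log units; within the scatter) and so leaves no reading difference between 2-methoxyphenyl and 3-methoxyphenyl on a carbonyl carbon. Among the compounds shown here, the earlier pair showed only one methoxyphenyl group set against 4-chlorophenyl, whereas a 2.4-fold lower number from compound 1 to compound 3 (0.38 log units; beyond the scatter) shows that the second methoxyphenyl group also stands apart from 4-chlorophenyl beyond the scatter. No evidence at hand accounts for these results.

The compounds shown leave open whether the separation from compound 1 follows the change of group or the place it occupies on the ring, a question that 4-methoxyphenyl or 2-chlorophenyl would address. They also leave open how a phenyl ring with no further group, or one bearing an ethoxy group, an amine or a carboxylic acid, would read here.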